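The source may report more compounds than this note shows. Statements on the series, on what has been measured and on what is new or still open speak of the compounds shown alone.

Compound 1 `CC(=O)Oc1c(C(C)C)cc2c3c1OC(=O)[C@@]31CCCC(C)(C)[C@@H]1CC2` is a diterpenoid lactone ester. In an ADME assay on MRC5 cells (Homo sapiens) for cytotoxicity, read by neutral red uptake, with a stated time of 24 h (a higher number here means a weaker inhibitor, a lower number a stronger inhibitor), compound 1 gives 290000 nM, the second highest of three numbers. Compound 2 `CCCC(=O)Oc1c(C(C)C)cc2c3c1OC(=O)[C@@]31CCCC(C)(C)[C@@H]1CC2` gives 44400 nM, and compound 3 `CC(C)c1cc2c3c(c1OC(=O)c1cccnc1)OC(=O)[C@@]31CCCC(C)(C)[C@@H]1CC2` gives 296000 nM. The step of a 6.5-fold lower number from compound 1 to compound 2 (0.82 log units; beyond the scatter) shows that a larger group on the saturated chain carbon bound to the carbonyl carbon lowered the number, while a 1.0-fold higher number from compound 1 to compound 3 (0.01 log units; within the scatter) shows that an aromatic ring on the carbonyl carbon itself changed nothing beyond the scatter. Compound 4 `CC(C)c1cc2c3c(c1OC(=O)Cc1c[nH]c4ccccc14)OC(=O)[C@@]31CCCC(C)(C)[C@@H]1CC2` carries 1H-indol-3-yl in place of hydrogen on a saturated chain carbon bound to a carbonyl carbon, a change at the same place as in compound 2 but with a larger aromatic group. A modest lowering is therefore expected, a 3.6-fold lower number from compound 1 to compound 4 (0.56 log units; beyond the scatter), and compound 4 is estimated at 80000 nM, between 20000 nM and 300000 nM.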

Compound 4, half-maximal inhibitory concentration: 109000 nM
Compound 4: middle estimate off by 1.4-fold (0.13 log units), on the low side; low and high end bracket the measured number.
By their numbers in this assay, from the lowest: compound 2; then compound 4; then compounds 1 and 3 (each within the scatter of the next).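

On the saturated chain carbon bound to a carbonyl carbon, 1H-indol-3-yl also lowers the number in this assay (a 2.7-fold lower number from compound 1 to compound 4 (0.42 log units; beyond the scatter)), so lowering here is not confined to ethyl. The indole still falls short of ethyl (a 2.5-fold higher number from compound 2 to compound 4 (0.39 log units; beyond the scatter)), and (1H-indol-3-yl)methyl on the carbonyl carbon gives a lower number than pyridin-3-yl (a 2.7-fold lower number from compound 3 to compound 4 (0.43 log units; beyond the scatter)). No measured evidence accounts for these steps. The compounds shown leave open whether a longer chain, such as hexyl, would lower the number further than ethyl. They also leave open how an amine at this place would behave.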